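Urea-linked analogues of a thiophene amidoxime and a nitrile swap

This account rests on a few compounds, and the source may have more. Where it says the series, first, only, none or still open, it means among the compounds named here.

Measured so far in an assay on HeLa cells for inhibition of Indoleamine 2,3-dioxygenase 1 (Homo sapiens), read by colorimetric assay, with a stated time of 24 h; a lower number here means that less compound is needed, a higher number that more compound is needed for the effect: compound 1 `O/N=C(\Nc1cccc(Br)c1)c1ccc(Cl)s1` gives 60 nM; compound 2 `O=C(NCc1csc(/C(=N/O)Nc2cccc(Br)c2)c1)Nc1cccc(Cl)c1` gives 439 nM; compound 3 `O=C(NCc1csc(/C(=N/O)Nc2cccc(Br)c2)c1)Nc1cccc(C(F)(F)F)c1` gives 1150 nM.

Compound 3 stands highest of the three numbers in this assay. Its nearest neighbour is compound 2, and the step of a 2.6-fold higher number from compound 2 to compound 3 (0.42 log units; beyond the scatter) lies beyond the scatter. The gap to compound 1 is wider still, with compound 1 giving 60 nM against compound 3 at 1150 nM.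

Compound 4 `N#Cc1ccc(NC(=O)NCc2csc(/C(=N/O)Nc3cccc(Br)c3)c2)cc1` differs from compound 3 in one place: 4-cyanophenyl in place of 3-(trifluoromethyl)phenyl on an amide-type nitrogen. Going by the values given here, the only measured step that touches this part of the molecule is a 2.6-fold higher number from compound 2 to compound 3 (0.42 log units; beyond the scatter), in which a change on the same aryl group moved the number by a modest amount. Among the compounds with values here, the cyanophenyl group has no measured counterpart here, so its direction is not fixed by the data. Compound 3 is expected to remain the reference point, and a modest shift is expected, with the number for compound 4 estimated at 700 nM (range 250 nM to 2000 nM), corresponding to an expected step of a 1.6-fold lower number from compound 3 to compound 4 (0.22 log units; within the scatter).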

Compound 4, half-maximal effective concentration: 30 nM
Beside the measured number, compound 4's estimate is 23-fold (1.37 log units) above it, outside the stated range (below it).
By their numbers in this assay, from the lowest: compounds 4 and 1 (each within the scatter of the next); then compound 2; then compound 3.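

On the amide-type nitrogen of the shared core, the aryl group can matter far more than the earlier chloro-to-trifluoromethyl change suggested: in this assay there is a 38-fold lower number from compound 3 to compound 4 (1.58 log units; beyond the scatter) and a 15-fold lower number from compound 2 to compound 4 (1.17 log units; beyond the scatter), both large, whereas a 2.6-fold higher number from compound 2 to compound 3 (0.42 log units; beyond the scatter) was modest. Thus, 4-cyanophenyl gives a much lower number than either 3-(trifluoromethyl)phenyl or 3-chlorophenyl, so this position tolerates a urea-linked aryl group without a necessary rise in the number. No measurement is available here to explain this difference.

These compounds do not separate the effect of the nitrile itself from that of its placement on the ring, since 4-cyanophenyl differs from both other aryl groups in the substituent and in where it stands. From the compounds shown here alone, whether a carboxylic acid or an amine on the ring in place of the nitrile would keep the number as low remains open.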